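From Cyclopentylcarbonyl to Methylsulfonyl on a Ring Nitrogen

The compounds below may be only part of what the source reports. "The series", "measured", "known", "first", "only" and "open" are said of these compounds alone.

Measured so far in a physicochemical assay for lipophilicity, at pH 7.4; on this read-out lower numbers stand for lower lipophilicity and higher numbers for higher lipophilicity:
Compound 1 `CCc1ccc(N(CC(C)C)S(=O)(=O)c2ccc(OCC3CCOCC3)c3c2CCC3=O)cc1`: 4.44
Compound 2 `CCc1ccc(N(CC(C)C)S(=O)(=O)c2ccc3c(c2)C(=O)CC(C2CCN(C(=O)C4CCCC4)CC2)O3)cc1`: 5.13

Of these two compounds, compound 2 stands highest at 5.13, and the gap down to compound 1 lies beyond the scatter. Compound 3 `CCc1ccc(N(CC(C)C)S(=O)(=O)c2ccc3c(c2)C(=O)CC(C2CCN(S(C)(=O)=O)CC2)O3)cc1` has not yet been measured. It differs from compound 2 in one place: methylsulfonyl in place of cyclopentylcarbonyl on an amine nitrogen in a ring. Methylsulfonyl thus takes the place of cyclopentylcarbonyl on an amine nitrogen in a ring. For the measured compounds named here, no measured pair shows this change, so the expectation rests on the structural change alone. The expected step, a number 0.83 log units lower from compound 2 to compound 3 (beyond the scatter), is a fall in this assay that goes beyond the scatter. For compound 3 the estimated value is 4.3, with an expected range from 3.8 to 4.7.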

Compound 3, distribution coefficient: 3.31
The estimate for compound 3 lay 0.99 log units above the measured number; the whole stated range lies above it.
By their numbers in this assay, from the lowest: compound 3; then compound 1; then compound 2.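

In this assay, for the compounds shown here, the amine nitrogen in the six-membered non-aromatic ring proves to be a place where a single exchange moves the read-out a long way: methylsulfonyl in place of cyclopentylcarbonyl gives a number 1.82 log units lower from compound 2 to compound 3 (beyond the scatter) and supplies the first step between compounds that differ in one place. The exchange removes the five-membered carbon ring and brings in sulfur at the same time, so this one step cannot be divided between those differences. Nothing measured here gives a reason for the size of the step.

The compounds shown leave open how much of the step belongs to the carbonyl-to-sulfonyl change and how much to the loss of the ring, which acetyl or cyclopentylsulfonyl on the same nitrogen would help to separate. On these data alone, whether the exchange gives a step of similar size on another core also remains open.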